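Methyl for Methoxy on the Fused Ring of Compound 2

This account rests on a few compounds, and the source may have more. Where it says the series, first, only, none or still open, it means among the compounds named here.

Of the compounds shown here, three share one core and have been measured. In an in vitro assay on BTI-TN-5B1-4 cells for inhibition of Amine oxidase [flavin-containing] B (Homo sapiens) (a lower number here means a stronger inhibitor, a higher number a weaker inhibitor), compound 2 `COc1ccc2c(c1)OC(c1ccccc1)CC2=O` gives 1470 nM, the highest of the three numbers. Compound 3 `COc1ccc2c(c1)OC(c1ccc(C)cc1)CC2=O` gives 550 nM and compound 1 `Cc1ccc(C2CC(=O)c3ccc(C)cc3O2)cc1` gives 500 nM, both beyond the scatter from compound 2. The step of a 2.7-fold lower number from compound 2 to compound 3 (0.43 log units; beyond the scatter) is a methyl in place of hydrogen on an aromatic carbon. Compound 4 `Cc1ccc2c(c1)OC(c1ccccc1)CC2=O` differs from compound 2 by methyl in place of methoxy on an aromatic carbon. The measured step that bears on this change is a 1.1-fold higher number from compound 1 to compound 3 (0.04 log units; within the scatter), which exchanges the same two groups at the same place and stays within the scatter. Compound 4 is therefore expected to show no change beyond the scatter in this assay, an expected step of a 1.1-fold lower number from compound 2 to compound 4 (0.02 log units; within the scatter). Compound 4 is estimated at 1400 nM, between 700 nM and 2800 nM.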

Compound 4, half-maximal inhibitory concentration: 3620 nM
Beside the measured number, compound 4's estimate is 2.6-fold (0.41 log units) below it; the whole stated range lies below it.
By their numbers in this assay, from the lowest: compounds 1 and 3 (each within the scatter of the next); then compound 2; then compound 4.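

Methyl in place of methoxy is not a neutral exchange at this position: it gives a 2.5-fold higher number from compound 2 to compound 4 (0.39 log units; beyond the scatter), and its effect depends on the core that carries it: the same change on two cores in this assay, a 1.1-fold higher number (0.04 log units; within the scatter) from compound 1 to compound 3 and a 2.5-fold lower number (0.39 log units; beyond the scatter) from compound 4 to compound 2, 2.7-fold (0.43 log units) apart, beyond the scatter of two such steps

Hydrogen in place of methyl gives a 7.2-fold higher number from compound 1 to compound 4 (0.86 log units; beyond the scatter), and this change also differs between cores: the same change on two cores in this assay, a 2.7-fold lower number (0.43 log units; beyond the scatter) from compound 2 to compound 3 and a 7.2-fold lower number (0.86 log units; beyond the scatter) from compound 4 to compound 1, 2.7-fold (0.43 log units) apart, beyond the scatter of two such steps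

Across these four compounds, then, the two changes do not act independently of each other.

Still open, going by these compounds, is how an amine, a chlorine or a longer chain such as ethoxy would behave at this position, on either core.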